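A few compounds are considered here, and "the series" means these few. Any claim that something is new, unique, unknown or untested is made for them only; others in the source may bear on it.

Compound 1 `CN(C[C@H]1Cc2c(cccc2N2CCN(Cc3ccccn3)CC2)CN1)[C@H]1CCCc2cccnc21`: > 30000 nM
Compound 2 `CN1CCN(c2cccc3c2C[C@H](CN(C)[C@H]2CCCc4cccnc42)N(C)C3)CC1`: > 30000 nM
Compound 3 `CC(C)N(C[C@H]1Cc2c(cccc2N2CCNCC2)CN1)[C@H]1CCCc2cccnc21`: > 30000 nM

These three compounds were tested in a functional assay on CCRF-CEM cells for agonist activity at C-X-C chemokine receptor type 4 (Homo sapiens), read by calcium flux, with a stated time of 25 min; a higher number here means that more compound is needed for the effect, a lower number that less compound is needed. For compound 1 the result > 30000 nM is a limit of the assay and not a number. Compound 2 likewise reaches only a limit. Compound 3 also reaches only a limit. So compound 1 stands nowhere in particular among the three: the limit of > 30000 nM in this assay, at which 3 of the 3 values shown sit, and no compound has a number that would set it apart from the others.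

Compound 4, `CN(C[C@H]1Cc2c(cccc2N2CCN(c3ccccn3)CC2)CN1)[C@H]1CCCc2cccnc21`, is not yet measured. It differs from compound 1 in one place: pyridin-2-yl in place of (pyridin-2-yl)methyl on an amine nitrogen in a ring. Among the compounds with values here, no pair of measured compounds differs in a single place, so no measured step shows what such a change does in this assay. With every measured value sitting at the limit, the expectation for compound 4 in this assay is again a limit rather than a number, and the change from compound 1 is expected to move the result by nothing beyond the scatter, though a step cannot be sized from a limit. Compound 4 is therefore estimated at 40000 nM, within 10000 nM to 200000 nM. The step that the limit leaves unreadable from compound 1 to compound 4 is what this estimate expects.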

Compound 4, half-maximal effective concentration: > 30000 nM
Compound 4 was reported as a limit (the forecaster's own chance of this, stated with the estimate: 85%); the middle value does not contradict the limit.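

Compound 1 and compound 4 both end at a limit of the assay and not at a number, so the step between them cannot be read in this assay: the limit of > 30000 nM in this assay, at which 4 of the 4 values shown sit.

The compounds shown leave open whether pyridin-2-yl, (pyridin-2-yl)methyl or any other change to the shared core alters the result at all.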